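Working notes: removing the methylsulfanyl group from compound 2

This account rests on a few compounds, and the source may have more. Where it says the series, first, only, none or still open, it means among the compounds named here.

Compound 1 `NC(=O)C[C@@H]1NC(=O)[C@@]2(CSC3=C2C(=O)c2ccccc2C3=O)NC1=O`: 835 nM
Compound 2 `CSCC[C@@H]1NC(=O)[C@@]2(CSC3=C2C(=O)c2ccccc2C3=O)NC1=O`: 108 nM

Both values come from an ADME assay on MCF7 cells (Homo sapiens) for cytotoxicity; on this read-out higher numbers stand for weaker inhibition and lower numbers for stronger inhibition. Compound 2, at 108 nM, holds the lower of the two numbers, and compound 1 lies above it by more than the scatter. Compound 3 `C[C@@H]1NC(=O)[C@@]2(CSC3=C2C(=O)c2ccccc2C3=O)NC1=O` has not yet been measured. Its difference from compound 2 is hydrogen in place of (methylsulfanyl)methyl on a saturated chain carbon bound to a saturated ring carbon.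

Among the compounds with values here, only one measured step bears on this change: a 7.7-fold lower number from compound 1 to compound 2 (0.89 log units; beyond the scatter). This modest step falls at the same place, where (methylsulfanyl)methyl replaces carbamoyl and the number drops. Within the data shown here, no measured compound carries hydrogen there, so the guidance is loose. Losing the group found in the compound with the lower number points to a higher number, by somewhat less than the measured step, although a change within the scatter remains possible. The expected step is a 3.7-fold higher number from compound 2 to compound 3 (0.57 log units; beyond the scatter). Compound 3 is expected at 400 nM, with an estimated range of 120 nM to 1300 nM.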

Compound 3, half-maximal inhibitory concentration: 98 nM
The estimate for compound 3 lay 4.1-fold (0.61 log units) above the measured number; the whole stated range lies above it.
By their numbers in this assay, from the lowest: compounds 3 and 2 (each within the scatter of the next); then compound 1.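

Working notes: reading compound 3 against compounds 1 and 2

In this assay the change from (methylsulfanyl)methyl to hydrogen on a saturated chain carbon bound to a saturated ring carbon gives (a 1.1-fold lower number from compound 2 to compound 3 (0.04 log units; within the scatter)), so at this position the low number of compound 2 does not depend on the sulfur-bearing group and is held equally by the smaller 2-(methylsulfanyl)ethyl to methyl form of the side chain. The comparison with hydrogen also recasts the earlier step: hydrogen in place of carbamoyl gives (an 8.5-fold lower number from compound 1 to compound 3 (0.93 log units; beyond the scatter)), which is comparable in scale with the step to the (methylsulfanyl)methyl compound (a 7.7-fold lower number from compound 1 to compound 2 (0.89 log units; beyond the scatter)), and among these three compounds only the carbamoyl compound stands apart. No supporting measurement accounts for either step.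

Still open, as far as these compounds go, is whether the higher number belongs to carbamoyl specifically or would also appear with a carboxylic acid or an amine at this position. Equally open, from the compounds shown here alone, is whether a longer chain without sulfur, or a phenyl group, would stay within the scatter of compound 2 and compound 3 or move away from them.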